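The compounds below may be only part of what the source reports. "The series", "measured", "known", "first", "only" and "open" are said of these compounds alone.

Measured compounds:
- compound 1, `Nc1scc(-c2ccc(F)cc2)c1C(=O)c1ccccc1`: 60%
- compound 2, `Nc1scc(-c2ccccc2F)c1C(=O)c1ccc(Cl)cc1`: 87%
- compound 3, `Nc1scc(-c2cccc(F)c2)c1C(=O)c1ccc(Cl)cc1`: 90%

All three were run in a functional assay on CHO cells for agonist activity at adenosine receptor A1 (Homo sapiens), read by fluorescence and ERK phosphorylation, with stated times of 30 min and 1.5 h, tested at 10 uM; on this read-out higher numbers stand for a stronger effect at the one concentration tested and lower numbers for a weaker effect. Compound 3 stands at the highest of the three numbers, but its nearest neighbour is compound 2, with the step of a number 3 percentage points higher from compound 2 to compound 3 (within the scatter) lying within the scatter, so the two cannot be ordered. Within the data shown here, compound 1 is the furthest away, with a lower number, a gap that lies beyond the scatter; compound 1 differs from compound 3 in two places, however, and no single step joins them.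

Compound 4, `Nc1scc(-c2ccc(F)cc2)c1C(=O)c1ccc(Cl)cc1`, is not yet measured. It differs from compound 3 by 4-fluorophenyl in place of 3-fluorophenyl on an aromatic carbon.

Among the measured compounds shown here, the one measured step that bears on this is a fluorine shift on the same ring, from compound 2 to compound 3: a number 3 percentage points higher from compound 2 to compound 3 (within the scatter), within the scatter. Moving the fluorine again on that ring is therefore not expected to produce a step beyond the scatter; the expected step of a number 5 percentage points lower from compound 3 to compound 4 (within the scatter) is small and without a clear direction. Compound 1, which carries the same 4-fluorophenyl as compound 4 but lacks the chlorine on the other ring, gives a lower number, yet that pair is not a single-change step and is not used here.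

Compound 4 is therefore estimated at 85%, within a range of 65% to 98%.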

Compound 4, a percentage reported as activity, at one concentration (the size of the read-out at that concentration, not a potency): 61%
Estimate against measurement, compound 4: 24 percentage points above, outside the stated range (below it).
By their numbers in this assay, from the lowest: compounds 1 and 4 (each within the scatter of the next); then compounds 2 and 3 (each within the scatter of the next).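

In this assay the position on the five-membered aromatic ring with 1 sulfur proves sensitive to where the fluorine sits on its phenyl group, which the earlier step, a number 3 percentage points higher from compound 2 to compound 3 (within the scatter), could not show. 4-Fluorophenyl in place of 3-fluorophenyl gives a number 29 percentage points lower from compound 3 to compound 4 (beyond the scatter), and 4-fluorophenyl in place of 2-fluorophenyl gives a number 26 percentage points lower from compound 2 to compound 4 (beyond the scatter), so among these three isomers the 4-fluorophenyl compound separates from the other two, while chloro in place of hydrogen on an aromatic carbon, with 4-fluorophenyl held constant, gives a number 1 percentage points higher from compound 1 to compound 4 (within the scatter) and leaves no readable difference. Nothing available explains the separation of the 4-fluorophenyl compound.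

Whether the chloro group is equally without a readable effect alongside 2-fluorophenyl or 3-fluorophenyl stays open, since the compounds shown hold no hydrogen-for-chloro pair with either group. Also open, going by these compounds, is how an unsubstituted phenyl, or a methoxy or a hydroxyl group in place of the fluorine of 4-fluorophenyl, would read at this position, and the single concentration gives the size of the effect only, not a potency for any compound.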